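The compounds below may be only part of what the source reports. "The series", "measured", "known", "first", "only" and "open" are said of these compounds alone.

Measured compounds:
- compound 1, `COC(=O)c1c(Cl)cc(Cl)cc1OC(=O)COc1cc(O)c2c(=O)cc(-c3ccccc3)oc2c1`, 345000 nM
- compound 2, `C=C(CCc1cc(O)c2c(=O)cc(-c3ccccc3)oc2c1)Cc1c(Br)cccc1C(=O)CC`, 379000 nM
- compound 3, `COC(=O)c1ccc(C)cc1OC(=O)COc1cc(O)c2c(=O)cc(-c3ccccc3)oc2c1`, 250000 nM

All three were run in an ADME assay on cells (T-cell, Mus musculus, strain BALB/c) for cytotoxicity, read by MTT assay, with a stated time of 48 h; on this read-out higher numbers stand for lower toxicity in this test and lower numbers for higher toxicity in this test. Among the compounds with values here, compound 3 stands at the low end of the three numbers, but its gap to compound 1 and its gap to compound 2 both lie within the usual scatter, so the three compounds cannot be told apart on these numbers; nothing more than that can be read from the pair-wise comparisons, and no step between measured compounds is available.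

The next compound is compound 4, `COC(=O)c1cccc(C)c1OC(=O)COc1cc(O)c2c(=O)cc(-c3ccccc3)oc2c1`, which shares every atom with compound 3 but joins them differently: a group of 11 heavy atoms (9 carbon, 2 oxygen; one six-membered aromatic ring of carbon only) in place of a group of 11 heavy atoms (9 carbon, 2 oxygen; one six-membered aromatic ring of carbon only), on an oxygen next to a carbonyl group. The change is confined to the group on an oxygen next to a carbonyl group, with the same count of heavy atoms and of donors and acceptors leaving and entering.

Within the data shown here, with no measured step to lean on, and with compound 1, compound 2 and compound 3 all sitting within scatter of one another despite larger structural differences, no step beyond the scatter is expected here in either direction. Compound 4 is expected to give 270000 nM in this assay, within 135000 nM to 540000 nM. The estimated step from compound 3 to compound 4 is a 1.1-fold higher number from compound 3 to compound 4 (0.03 log units; within the scatter).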

Compound 4, half-maximal cytotoxic concentration: 299000 nM
Beside the measured number, compound 4's estimate is 1.1-fold (0.04 log units) below it, within the range that was stated.
By their numbers in this assay, from the lowest: compounds 3, 4, 1 and 2 (each within the scatter of the next).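

In this assay, within the data shown here, the one-place step between these two isomers is a 1.2-fold higher number from compound 3 to compound 4 (0.08 log units; within the scatter), the first step that can be read at a single place, and it lies within the scatter. At the position on an oxygen next to a carbonyl group, the leaving and entering groups have the same heavy atoms, the same six-membered aromatic ring of carbon only, the same double bond outside aromatic rings and the same count of hydrogen-bond acceptors, so only the way the atoms are joined differs, and that difference does not separate compound 3 from compound 4 on this read-out. No measured evidence bears on this result.

Still open, from the compounds shown here alone, is whether a group of different make-up at this place, such as an amine or a carboxylic acid on the aromatic ring of the group, would give a step beyond the scatter in this assay. Also open, going by these compounds, is whether compound 3 and compound 4, which cannot be told apart here, would stay together on a read-out of another kind.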